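The compounds below may be only part of what the source reports. "The series", "measured", "known", "first", "only" and "open" are said of these compounds alone.

Compound 2, with the structure `Cc1cc(/C=C/c2ccc(O)cc2)on1`, was tested in a functional assay on PC-3 cells (Homo sapiens) for cytotoxicity, read by MTT assay, with a stated time of 72 h (a higher number here means a weaker inhibitor, a lower number a stronger inhibitor), and gave 50200 nM. For the measured compounds named here, its only measured companion is compound 1, `COc1cc(/C=C/c2cc(C)no2)ccc1O`, which in this assay gave 20900 nM; the step from one to the other, a change of hydrogen in place of methoxy on an aromatic carbon, read a 2.4-fold higher number from compound 1 to compound 2 (0.38 log units; beyond the scatter). Going by the values given here, compound 2 therefore stands at the highest of the two numbers so far, with compound 1 the nearer and lower of them.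

Compound 3, `COc1ccc(/C=C/c2cc(C)no2)cc1`, has not yet been measured in this assay. It differs from compound 2 by methyl in place of hydrogen on an oxygen on an aromatic ring. Among the compounds with values here, no measured step touches this position: the one step available concerns a different site on the same ring, so it offers no direct guide. With nothing to point in either direction, compound 3 is expected to land near compound 2, with a step of about a 1.1-fold lower number from compound 2 to compound 3 (0.05 log units; within the scatter) that is not expected to exceed the scatter. The estimate for compound 3 in this assay is therefore 45000 nM, within a range from 15000 nM to 130000 nM.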

Compound 3, half-maximal inhibitory concentration: > 100000 nM
Compound 3: a limit, no number (the forecaster's own chance of this, stated with the estimate: 15%); middle value at least 2.2-fold (0.34 log units) away from the limit.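

In this assay compound 3 carries a limit and not a number: the limit of > 100000 nM in this assay, at which 1 of the 3 values shown sits. The change from hydroxy to methoxy is the first one shown on the oxygen itself, and it reads an at least 1.9-fold higher number from compound 2 to compound 3 (0.29 log units; that floor lies within the scatter), so only a floor for its size can be given and the true size stays unknown. Even so, the limit leaves no room for compound 3 to sit lower than compound 2, which gives this position a direction that the earlier step, made at a different site on the same ring, could not give.

Only hydrogen and methyl are shown on this oxygen, so it remains open how far the number would move with an ethyl, a longer chain or an acetyl there, or with an amine in place of the hydroxy. As far as these compounds go, it is also open whether methyl on this oxygen would read the same way on the core of compound 1, where the methoxy on the aromatic carbon is still present.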